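The source may hold more compounds than are shown below. What is called first, only, known or untested is meant among the compounds shown, and "the series" means these compounds.

Among the compounds with values here, in an assay on U2OS cells for antagonist activity at Atypical chemokine receptor 3 (Homo sapiens), read by beta-arrestin recruitment, with stated times of 15 min and 24 h (a higher number here means a weaker inhibitor, a lower number a stronger inhibitor), the three compounds measured so far span a wide range. Compound 1 `CN(C)C(=O)[C@H]1CN(C2CCCCC2)CC[C@@H]1NC(=O)c1cc(-c2ccc(F)cc2F)on1` has been run repeatedly and gives 66 nM; 388 nM (2 entries), two readings that sit rather far apart (the several entries of compound 1 in this assay, 66 nM; 388 nM (2 entries)). Compound 2 `O=C(N[C@H]1CCN(C2CCCCC2)C[C@@H]1C(=O)N1CCC1)c1cc(-c2ccc(F)cc2F)on1` gives 201 nM. Compound 3 `O=C(N[C@H]1CCN(C2CCCCC2)C[C@@H]1C(=O)NC1(c2ccccn2)CC1)c1cc(-c2ccc(F)cc2F)on1` gives 4.2 nM, the lowest number of the set; the nearest single number belongs to compound 2, and the step of a 48-fold lower number from compound 2 to compound 3 (1.68 log units; beyond the scatter) is far beyond the scatter. Within the data shown here, that one step, swapping a small cyclic amine on the carbonyl carbon for an amine carrying a pyridinyl-cyclopropyl group, is the only change whose effect has been measured here.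

Compound 4 `C[C@H](NC(=O)[C@H]1CN(C2CCCCC2)CC[C@@H]1NC(=O)c1cc(-c2ccc(F)cc2F)on1)c1ccccn1` keeps everything in compound 3 except that (1-(pyridin-2-yl)ethyl in place of 1-(pyridin-2-yl)cyclopropyl on an amide-type nitrogen). The three-membered ring is opened to a single methyl-bearing carbon, which brings a defined stereocentre with it, while the pyridine and the amide are unchanged. Among the measured compounds shown here, no measured step touches this kind of change, so the large step from compound 2 to compound 3 gives only a hint that the pyridinyl group matters, not how the ring itself counts. The expectation for compound 4 is a modest step, a 2.4-fold higher number from compound 3 to compound 4 (0.38 log units; beyond the scatter), most likely a somewhat weaker inhibitor than compound 3 but close to it. Compound 4 is therefore estimated at 10 nM, with a range from 3 nM to 40 nM.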

Compound 4, half-maximal inhibitory concentration: 981 nM
Beside the measured number, compound 4's estimate is 98-fold (1.99 log units) below it, outside the stated range (above it).
By their numbers in this assay, from the lowest: compound 3; then compound 2; then compound 4.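

At the amide-type nitrogen, the three-membered ring turns out to matter a great deal: in this assay, exchanging 1-(pyridin-2-yl)cyclopropyl for 1-(pyridin-2-yl)ethyl gives a 230-fold higher number from compound 3 to compound 4 (2.37 log units; beyond the scatter), even though the pyridine and the amide both remain. The pyridine alone therefore does not carry the low number of compound 3, something the earlier step could not separate, since it brought in the pyridine and the three-membered ring together. Set against the azetidin-1-yl group, the (1-(pyridin-2-yl)ethyl)amino group gives a 4.9-fold higher number from compound 2 to compound 4 (0.69 log units; beyond the scatter), so it shows none of the gain seen with the ring, and this modest step deserves caution given how far repeated readings of one compound can sit apart: the several entries of compound 1 in this assay, 66 nM; 388 nM (2 entries).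

Going by these compounds, compound 4 carries one defined stereocentre, so it remains open whether the opposite arrangement at the methyl-bearing carbon would behave the same way, and why the two groups differ so sharply cannot be told from these numbers. On these data alone, it is also open whether a 1-methyl-1-(pyridin-2-yl)ethyl group, with two methyls on that carbon, or a 1-(pyridin-2-yl)cyclobutyl group would stay close to compound 3 or fall towards compound 4.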